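Methoxymethyl capping across two related cores

This account rests on a few compounds, and the source may have more. Where it says the series, first, only, none or still open, it means among the compounds named here.

Compound 2 `CC/C=C\C/C=C\C/C=C\CCCCCCCC1(O)CC(=O)c2c(O)cc(O)cc2O1` carries a free hydroxy on an aromatic ring; compound 1 `CC/C=C\C/C=C\C/C=C\CCCCCCCC1(O)CC(=O)c2c(O)cc(OCOC)cc2O1` is its methoxymethyl ether. In a functional assay on MDA-MB-231 cells (Homo sapiens) for antiproliferative activity, read by MTT assay (on this read-out higher numbers stand for weaker inhibition and lower numbers for stronger inhibition), compound 2 gives 6790 nM and compound 1 gives 6790 nM, so the change methoxymethyl in place of hydrogen on an oxygen on an aromatic ring makes a step of no change at the digits printed from compound 2 to compound 1 (within the scatter). Compound 3 `CCCCC/C=C\C/C=C\CCCCCCCc1cc(=O)c2c(O)cc(O)cc2o1` rests on a different core; the difference between its core and that of compound 2 is not broken down here. In this assay compound 3 gives 6790 nM, level with compounds 1 and 2. Compound 4 `CCCCC/C=C\C/C=C\CCCCCCCc1cc(=O)c2c(O)cc(OCOC)cc2o1` applies the same change to compound 3, namely (methoxymethyl in place of hydrogen on an oxygen on an aromatic ring), at a place described in the same words as before. Among the measured compounds shown here, the only precedent for this change is the step of no change at the digits printed from compound 2 to compound 1 (within the scatter). On that basis the step from compound 3 to compound 4 is expected to be no change at the digits printed from compound 3 to compound 4 (within the scatter). Compound 4 is therefore estimated at 6790 nM, within a range from 3400 nM to 13600 nM.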

Compound 4, half-maximal inhibitory concentration: > 87000 nM
Compound 4: a limit, no number; the forecaster's own chance of this, stated with the estimate: 5%; middle value at least 12-fold (1.10 log units) from the limit.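

In this assay compound 4 gives > 87000 nM, which is a limit of the assay and not a number. On the core of compound 3 the change makes a step of an at least 12-fold higher number from compound 3 to compound 4 (1.10 log units; beyond the scatter), so the outcome on one core does not carry over to the other: the same change on two cores in this assay, no change at the digits printed (within the scatter) from compound 2 to compound 1 and an at least 12-fold higher number (1.10 log units; beyond the scatter) from compound 3 to compound 4, at least 12-fold (1.10 log units) apart, beyond the scatter of two such steps

As far as these compounds go, these two pairs do not show which difference between the cores goes with this gap, and the full size of the new step remains unknown.

Open, from the compounds shown here alone, is how a methyl or an acetyl group on the same oxygen would read on each core. Also open, going by these compounds, is whether either core would respond the same way to a methoxymethyl group on a shorter chain.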